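Terthiaryl pyridine series: adding a second thiophene

A few compounds are considered here, and "the series" means these few. Any claim that something is new, unique, unknown or untested is made for them only; others in the source may bear on it.

Compound 1 `c1coc(-c2ccnc(-c3cccs3)c2)c1` carries a furan-2-yl and a thiophen-2-yl on the shared core. In a functional assay on SK-OV-3 cells (Female gonad, Homo sapiens) for antiproliferative activity (on this read-out lower numbers stand for an effect already at smaller amounts and higher numbers for an effect only at larger amounts of compound), compound 1 gives 118000 nM. Its nearest neighbour on the numbers is compound 2 `c1ccc(-c2cc(-c3ccco3)ccn2)nc1`, which in this assay gives 118000 nM; the two values are level at the digits shown, so the pair says nothing about a direction. Within the data shown here, no step between measured compounds that differ in a single place is available.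

Compound 3 `c1coc(-c2cc(-c3cccs3)nc(-c3cccs3)c2)c1` is the compound of interest. From compound 1 it differs by thiophen-2-yl in place of hydrogen on an aromatic carbon next to the ring nitrogen, meta to the furan-2-yl group and meta to the thiophen-2-yl group already present.

Among the measured compounds shown here, with no measured step of this kind, the size of the change in this assay is open. Given that compound 1 sits at 118000 nM, a move beyond the scatter in either direction is possible, and a modest gain is taken as the more likely case, expected as a 2.0-fold lower number from compound 1 to compound 3 (0.29 log units; within the scatter). Compound 3 is therefore estimated at 60000 nM, with a range from 15000 nM to 200000 nM.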

Compound 3, half-maximal effective concentration: 118000 nM
Estimate against measurement, compound 3: 2.0-fold (0.29 log units) below, within the range that was stated.
By their numbers in this assay, from the lowest: compounds 1, 2 and 3 (each within the scatter of the next).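

Thiophen-2-yl in place of hydrogen gives the first readable step in this series, on an aromatic carbon next to the ring nitrogen: in this assay the step reads no change at the digits printed from compound 1 to compound 3 (within the scatter), and the value of compound 1 offers no direction for this change. This position therefore accepts a second thiophen-2-yl, meta to the furan-2-yl group and meta to the thiophen-2-yl group already present, with no shift in the number at the digits printed, so the added five-membered aromatic ring brings neither gain nor loss in this read-out. No supporting measurement bears on this result.

Going by these compounds, whether this position stays equally flat with an amine, a carboxylic acid or a longer alkyl chain in place of hydrogen remains open. Also open, on these data alone, is whether thiophen-2-yl on another carbon of the shared core would leave the number just as unchanged.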